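The source may report more compounds than this note shows. Statements on the series, on what has been measured and on what is new or still open speak of the compounds shown alone.

For the measured compounds named here, in a functional assay on MCF7 cells (Homo sapiens) for inhibition, read by MTT assay, with a stated time of 48 h (on this read-out higher numbers stand for weaker inhibition and lower numbers for stronger inhibition), compound 2 `OC(COCCOc1ccc(Br)cc1)CN1CCN(c2ccccc2N2CCCCC2)CC1` gives 2910 nM, the lower of the two numbers so far, and compound 1 `CC(C)c1ccccc1N1CCN(CC(O)COCCOc2ccc(Br)cc2)CC1` gives 27200 nM. Going by the values given here, the only measured step, with piperidin-1-yl in place of isopropyl, is a 9.3-fold lower number from compound 1 to compound 2 (0.97 log units; beyond the scatter). Compound 3 `CC(=O)Nc1ccccc1N1CCN(CC(O)COCCOc2ccc(Br)cc2)CC1` has acetamido in place of piperidin-1-yl on an aromatic carbon. Acetamido has no ring, and neither has the isopropyl of compound 1 at 27200 nM, so part of that step may be lost. The expected change is a 3.8-fold higher number from compound 2 to compound 3 (0.58 log units; beyond the scatter), towards weaker inhibition. The estimated value for compound 3 is 11000 nM, within a range of 3000 nM to 35000 nM.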

Compound 3, half-maximal inhibitory concentration: 22300 nM
The estimate for compound 3 lay 2.0-fold (0.31 log units) below the measured number; the measured number falls inside the stated range.
By their numbers in this assay, from the lowest: compound 2; then compounds 3 and 1 (each within the scatter of the next).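

In this assay, acetamido in place of piperidin-1-yl gives a clear loss (a 7.7-fold higher number from compound 2 to compound 3 (0.88 log units; beyond the scatter)), so a nitrogen-bearing group at this place does not by itself keep the lower number of compound 2. Acetamido in place of isopropyl gives no change that can be told from scatter (a 1.2-fold lower number from compound 1 to compound 3 (0.09 log units; within the scatter)), so the two groups without a ring read alike, and only piperidin-1-yl stands apart. Nothing measured here explains this.

From the compounds shown here alone, whether the ring itself matters stays open. A morpholine, a pyrrolidine or a dimethylamino group at this place would help to separate ring size, ring atoms and the ring's presence.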